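Dichlorophenyl Replaces Methoxypyridine on the Chalcone Arm

The compounds below may be only part of what the source reports. "The series", "measured", "known", "first", "only" and "open" are said of these compounds alone.

Compound 1 `COc1ccc(C(=O)/C=C/c2ccc(F)cc2)c2c1C=CC(C)(C)O2` gives > 10000 nM in a functional assay on HCT-116 cells (Homo sapiens) for antiproliferative activity, read by MTT assay, with a stated time of 24 h; on this read-out higher numbers stand for weaker inhibition and lower numbers for stronger inhibition; this is a limit of the assay, not a number.
Compound 2 `COc1ccc(C(=O)/C=C/c2ccc(N(C)C)cc2)c2c1C=CC(C)(C)O2` gives 1920 nM in this assay.
Compound 3 `COc1ccc(/C=C/C(=O)c2ccc(OC)c3c2OC(C)(C)C=C3)cn1` gives > 10000 nM in this assay; this too is a limit.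

Compound 3 therefore stands at the ceiling of what was measured, with only a range known, and (the limit of > 10000 nM in this assay, at which 2 of the 3 values shown sit). Compound 4 `COc1ccc(C(=O)/C=C/c2ccc(Cl)c(Cl)c2)c2c1C=CC(C)(C)O2` differs from it by 3,4-dichlorophenyl in place of 6-methoxypyridin-3-yl on a double-bonded chain carbon bound to a double-bonded chain carbon. Going by the values given here, the step of an at least 5.2-fold higher number from compound 2 to compound 3 (0.71 log units; beyond the scatter) shows how far compound 3 sits from the one compound with a numerical value, while a step that the two limits leave unreadable from compound 1 to compound 3. Among the compounds with values here, the step of an at least 5.2-fold lower number from compound 1 to compound 2 (0.71 log units; beyond the scatter) is the only change that brought a number within range. Like compound 1, compound 4 bears halogens on this ring. Compound 4 is therefore expected to remain at the limit, a step that the limit leaves unreadable from compound 3 to compound 4, with an estimate of 15000 nM between 5000 nM and 50000 nM.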

Compound 4, half-maximal inhibitory concentration: 9440 nM
For compound 4 the middle estimate is 1.6-fold (0.20 log units) above the measured one, and the stated range covers the measured number.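

Swapping 6-methoxypyridin-3-yl for 3,4-dichlorophenyl gives an at least 1.0-fold lower number from compound 3 to compound 4 (0.02 log units; that floor lies within the scatter), and swapping 4-fluorophenyl for 3,4-dichlorophenyl gives an at least 1.0-fold lower number from compound 1 to compound 4 (0.02 log units; that floor lies within the scatter), so in this assay neither change is shown to strengthen inhibition. Both of these steps start from a limit: the limit of > 10000 nM in this assay, at which 2 of the 4 values shown sit. Among the groups at this place on the chain, 4-(dimethylamino)phenyl still gives the strongest inhibition, as 3,4-dichlorophenyl brings a 4.9-fold higher number from compound 2 to compound 4 (0.69 log units; beyond the scatter).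

Still open, as far as these compounds go, is whether another amine on this aromatic ring, such as morpholine or pyrrolidine, would give a lower number than compound 2 in this assay.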